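The source may hold more compounds than are shown below. What is called first, only, known or untested is meant among the compounds shown, and "the series" means these compounds.

Of the compounds shown here, two with a shared core have been measured in a functional assay on ACHN cells (Homo sapiens) for inhibition, read by sulforhodamine B assay, with a stated time of 48 h; a higher number here means that more compound is tolerated, a lower number that less compound is tolerated. Compound 1 `COc1cc2cc(Oc3ccc(NC(=O)Nc4cccc(C(F)(F)F)c4)cc3)c(C)nc2cc1OC` carries a trifluoromethyl group on its terminal aromatic ring; in this assay compound 1 reaches only a limit, > 50000 nM. Compound 2 `COc1cc2cc(Oc3ccc(NC(=O)Nc4ccc(Cl)c(C(F)(F)F)c4)cc3)c(C)nc2cc1OC` adds a chloro group to that ring, and in this assay compound 2 gives 13700 nM. Among the compounds with values here, the single measured step is an at least 3.6-fold lower number from compound 1 to compound 2 (0.56 log units; beyond the scatter). Compound 2 therefore holds the only real number shown; the other value is a limit, as in the limit of > 50000 nM in this assay, at which 1 of the 2 values shown sits.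

Compound 3 `COc1cc2cc(Oc3ccc(NC(=O)Nc4ccc(Cl)c(Cl)c4)cc3)c(C)nc2cc1OC` differs from compound 2 in one place: chloro in place of trifluoromethyl on an aromatic carbon. No measured step exchanges trifluoromethyl for chloro, so the only guide is that the neighbouring chloro group, present in both compound 2 and compound 3, has already been shown to matter in the step from compound 1 to compound 2. Keeping that group, the expected change in this assay from compound 2 to compound 3 is estimated to be small, a 1.1-fold higher number from compound 2 to compound 3 (0.04 log units; within the scatter), within the scatter. For compound 3 the estimated value in this assay is 15000 nM, with a likely range from 5000 nM to 45000 nM.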

Compound 3, concentration lethal to 50% of the cells: 69100 nM
Beside the measured number, compound 3's estimate is 4.6-fold (0.66 log units) below it, outside the stated range (above it).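

In this assay, exchanging trifluoromethyl for chloro at this position gives a 5.0-fold higher number from compound 2 to compound 3 (0.70 log units; beyond the scatter), so the group on this aromatic carbon counts in its own right, and here the lower number, meaning less compound tolerated, goes with trifluoromethyl. Within the data shown here, the earlier step showed only that adding a chloro group could change the number while trifluoromethyl stayed in place; that added chloro group is present in both compound 2 and compound 3, so on its own it does not keep the number low. The value of compound 1 is a limit and not a number, so its step to compound 3 cannot be read: the limit of > 50000 nM in this assay, at which 1 of the 3 values shown sits.

As far as these compounds go, it remains open whether trifluoromethyl is unusual at this position or whether another group, such as bromo, methyl or nitrile, would give a number close to that of compound 2. Also open, from the compounds shown here alone, is how a plain hydrogen at this place would read with the chloro group kept, as in a 4-chlorophenyl ring on the same shared core.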